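A few compounds are considered here, and "the series" means these few. Any claim that something is new, unique, unknown or untested is made for them only; others in the source may bear on it.

In a functional assay on DU-145 cells (Homo sapiens) for inhibition, read by trypan blue exclusion, with a stated time of 96 h (a lower number here means a stronger inhibitor of growth, a higher number a weaker inhibitor of growth), three closely related compounds have been measured. Compound 1 (`CCOc1ccc(/C=C(/SCc2ccc(F)cc2)C(=O)c2ccc(Br)cc2)cc1OC`) gives 50000 nM. Compound 2 (`CCOc1ccc(/C=C(/Sc2ccc(C)cc2)C(=O)c2ccc(Cl)cc2)cc1OC`) gives 25000 nM. Compound 3 (`CCOc1ccc(/C=C(/SCc2ccc(Cl)c(Cl)c2)C(=O)c2ccc(Cl)cc2)cc1OC`) gives 25000 nM, which places it level with compound 2, while compound 1 lies within the scatter of both.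

Compound 4 (`CCOc1ccc(/C=C(/SCc2ccc(F)cc2)C(=O)c2ccc(Cl)cc2)cc1OC`) differs from compound 3 by 4-fluorophenyl in place of 3,4-dichlorophenyl on a saturated chain carbon bound to a sulfur: 3,4-dichlorobenzyl on the sulfur becomes 4-fluorobenzyl. For the measured compounds named here, one measured step bears directly on this position, no change at the digits printed from compound 2 to compound 3 (within the scatter), a swap of the group on the same sulfur that left the number unmoved. Compound 4 shares the 4-fluorobenzyl group with compound 1, though the two differ elsewhere, and compound 1 at 50000 nM stays within the scatter of compound 3. With so few compounds the evidence is thin, but nothing in it points to a real shift. The expected result is a 1.2-fold higher number from compound 3 to compound 4 (0.08 log units; within the scatter), a step no larger than the scatter. For compound 4 the estimated value is 30000 nM, with an expected range of 14000 nM to 60000 nM.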

Compound 4, concentration for 50% growth inhibition: 1000 nM
Compound 4: middle estimate off by 30-fold (1.48 log units), on the high side, outside the stated range (below it).
By their numbers in this assay, from the lowest: compound 4; then compounds 2, 3 and 1 (each within the scatter of the next).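

In this assay the group on the sulfur proves able to move the number strongly: 4-fluorobenzyl in place of 3,4-dichlorobenzyl gives a 25-fold lower number from compound 3 to compound 4 (1.40 log units; beyond the scatter) while the earlier swap on that sulfur gave no change at the digits printed from compound 2 to compound 3 (within the scatter) and so had shown no such sensitivity. The same group in place of 4-methylphenyl gives a 25-fold lower number from compound 2 to compound 4 (1.40 log units; beyond the scatter) and, with 4-fluorobenzyl held fixed, chloro in place of bromo on an aromatic carbon gives a 50-fold lower number from compound 1 to compound 4 (1.70 log units; beyond the scatter) so that the low number needs both the 4-fluorobenzyl and the chloro in these compounds. Nothing measured here explains these steps.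

From the compounds shown here alone, how a plain benzyl, a 4-chlorobenzyl or a longer chain on the sulfur would read stays open. So does the outcome of a nitrile or an amine in place of the chloro on the aromatic carbon.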